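A few compounds are considered here, and "the series" means these few. Any claim that something is new, unique, unknown or untested is made for them only; others in the source may bear on it.

Compound 1 (`CSc1ncnc2c1c(-c1cccs1)cn2[C@@H]1O[C@H](CO)[C@@H](O)[C@H]1O`) stands at a limit, not a number: in a functional assay on HCT-116 cells (Homo sapiens), read by MTT assay, with a stated time of 72 h (on this read-out lower numbers stand for stronger inhibition and higher numbers for weaker inhibition), compound 1 gives > 20000 nM. Compound 2 (`CSc1ncnc2c1c(-c1ccccc1)cn2[C@@H]1O[C@H](CO)[C@@H](O)[C@H]1O`) is likewise only a limit, at > 20000 nM. These two share (the limit of > 20000 nM in this assay, at which 2 of the 3 values shown sit). Compound 3 (`C#Cc1cn([C@@H]2O[C@H](CO)[C@@H](O)[C@H]2O)c2ncnc(SC)c12`) gives a true number, 30 nM. The measured steps replace only thiophen-2-yl or phenyl: an at least 660-fold lower number from compound 1 to compound 3 (2.82 log units; beyond the scatter), an at least 660-fold lower number from compound 2 to compound 3 (2.82 log units; beyond the scatter), and a step that the two limits leave unreadable from compound 1 to compound 2. None touches methylsulfanyl, so none sizes the change to compound 4 (`Cc1ncnc2c1c(-c1cccs1)cn2[C@@H]1O[C@H](CO)[C@@H](O)[C@H]1O`), which has methyl in place of methylsulfanyl on an aromatic carbon. A moderate move toward lower numbers in this assay is expected, with the estimated step being an at least 4.0-fold lower number from compound 1 to compound 4 (0.60 log units; beyond the scatter). For compound 4 the estimated value is 5000 nM, expected between 300 nM and 20000 nM.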

Compound 4, half-maximal inhibitory concentration: > 20000 nM
Compound 4 gave a limit, no number; the forecaster's own chance of this, stated with the estimate: 40%; middle value at least 4.0-fold (0.60 log units) away from the limit.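

Compound 4, like compound 1, gives only a limit, so the step between these two compounds cannot be read: the limit of > 20000 nM in this assay, at which 3 of the 4 values shown sit.

The compounds shown leave open whether methyl in place of methylsulfanyl shifts the value at all.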